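This account rests on a few compounds, and the source may have more. Where it says the series, first, only, none or still open, it means among the compounds named here.

Measured in an in vivo ADME assay on the whole organism for pharmacokinetics, with Canis familiaris (Canis lupus familiaris) as the target, at a dose of 0.5 mg/kg by the intravenous route; on this read-out lower numbers stand for narrower distribution and higher numbers for wider distribution into tissues:

compound 1, `COc1cc2nc(N3CCCN(C(=O)N4CCOCC4)CC3)nc(N)c2c(-c2ccccn2)c1OC`, gives 4 L/kg
compound 2, `COc1cc2nc(N3CCCN(C(=O)N4CCOCC4)CC3)cc(N)c2c(-c2ccccc2)c1OC`, gives 23 L/kg
compound 3, `COc1cc2c(cc1OC)CN(c1nc(N3CCCN(C(=O)N4CC(O)C(O)C4)CC3)nc3cc(OC)c(OC)cc13)CC2`, gives 100 L/kg

Among these three numbers compound 2 stands second highest in this assay. Compound 3 gives the higher number of the three, and its gap to compound 2 lies beyond the usual scatter; compound 1 gives the lowest number, and its gap to compound 2 also lies beyond the scatter. No two of these compounds differ in one place only, so none of these gaps can be tied to a single structural change.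

Compound 4, `COc1cc2nc(N3CCCN(C(=O)N4CCOCC4)CC3)cc(N)c2c(-c2ccc(F)cc2)c1OC`, is not yet measured. It differs from compound 2 by fluoro in place of hydrogen on an aromatic carbon; seen one bond further out, phenyl becomes 4-fluorophenyl. Within the data shown here, no measured pair shows this change, so the data give no step to lean on. Given that, the account expects a step of a 1.1-fold higher number from compound 2 to compound 4 (0.04 log units; within the scatter) that stays within the usual scatter, with no confident direction. Compound 4 is estimated to give 25 L/kg, in the range from 10 L/kg to 60 L/kg.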

Compound 4, volume of distribution in the Canis familiaris assay: 96 L/kg
Compound 4: middle estimate off by 3.8-fold (0.58 log units), on the low side, and the stated range ends below it.
By their numbers in the Canis familiaris assay, from the lowest: compound 1; then compound 2; then compounds 4 and 3 (each within the scatter of the next).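

Among these compounds, this is the first comparison that differs in one place only, and it shows that the aromatic carbon para to a large group is not a silent position: in the Canis familiaris assay compound 2 gives 23 L/kg and compound 4 gives 96 L/kg, so fluoro in place of hydrogen gives a 4.2-fold higher number from compound 2 to compound 4 (0.62 log units; beyond the scatter) through that single change. In a physicochemical assay for lipophilicity, in phosphate buffer, at pH 7.4 (a higher number here means a more lipophilic compound, a lower number a more polar compound), compound 2 gives 1.8 and compound 4 gives 1.8; the same change shows no change at the digits printed from compound 2 to compound 4 (within the scatter) and so the two read-outs part ways at this position. Nothing at hand accounts for the step in distribution.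

As far as these compounds go, it remains open whether the step belongs to fluoro alone or whether chloro, methoxy or an amine at this place would give a step of similar size. Also open, from the compounds shown here alone, is whether phenyl to 4-fluorophenyl would carry the same step on another core, and one pair cannot settle this.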